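This account rests on a few compounds, and the source may have more. Where it says the series, first, only, none or still open, it means among the compounds named here.

Working notes on the series. In an assay on tissue (RPTEC cells) for inhibition of solute carrier family 22 member 12 (Homo sapiens), read by scintillation counting, with stated times of 15 min and 2 h (on this read-out higher numbers stand for weaker inhibition and lower numbers for stronger inhibition), compound 1 `Cc1c(C)n(C(=O)c2ccc(O)c(C#N)c2)c2ccccc12` gives 10800 nM. In this assay compound 2 `N#Cc1cc(C(=O)N2CCc3ccccc32)cc(C#N)c1O` gives 83900 nM, the higher of the two numbers, with the gap to compound 1 beyond the scatter. Compound 3 `N#Cc1cc(C(=O)N2CCc3ccccc32)cc(C(F)(F)F)c1O` differs from compound 2 by trifluoromethyl in place of cyano on an aromatic carbon. For the measured compounds named here, no pair of measured compounds shows this change, so its effect is unknown; the expected step of a 1.9-fold lower number from compound 2 to compound 3 (0.27 log units; within the scatter) is small, toward a somewhat lower number, with wide uncertainty. For compound 3 the estimate in this assay is 45000 nM, within a range of 12000 nM to 170000 nM.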

Compound 3, half-maximal inhibitory concentration: > 100000 nM
Compound 3 ended at the assay's limit; the forecaster's own chance of this, stated with the estimate: 10%; at least 2.2-fold (0.34 log units) between middle value and limit.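

The value of compound 3 in this assay, > 100000 nM, is a limit and not a number: the limit of > 100000 nM in this assay, at which 1 of the 3 values shown sits. Trifluoromethyl in place of cyano on this aromatic carbon, ortho to a hydroxy group, gives an at least 1.1-fold higher number from compound 2 to compound 3 (0.07 log units; that floor lies within the scatter), so the one reading of this change shows no move toward stronger inhibition. How far the step extends past that floor cannot be read.

On these data alone, whether an amine or a carboxylic acid on this carbon would give a lower number stays open. So does whether the same change on the core of compound 1 would behave alike.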